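A Trimethoxyphenyl Swap in a Cytotoxicity Series

This account rests on a few compounds, and the source may have more. Where it says the series, first, only, none or still open, it means among the compounds named here.

Of the compounds shown here, three built on one shared core have been tested in a functional assay on A549 cells (Homo sapiens) for cytotoxicity, read by MTT assay, with a stated time of 72 h; a lower number here means a stronger inhibitor, a higher number a weaker inhibitor. Compound 1 `N#Cc1ccc(/C=N/NC(=O)Nc2cc3c(Nc4ccc(F)c(Cl)c4)ncnc3cc2O[C@H]2CCOC2)cc1` gives 29100 nM. Compound 2 `O=C(N/N=C/c1ccc([N+](=O)[O-])cc1)Nc1cc2c(Nc3ccc(F)c(Cl)c3)ncnc2cc1O[C@H]1CCOC1` gives 31200 nM, and compound 3 `COc1ccc(/C=N/NC(=O)Nc2cc3c(Nc4ccc(F)c(Cl)c4)ncnc3cc2O[C@H]2CCOC2)c(OC)c1OC` gives 25200 nM. Compound 2 shows the highest of the three numbers, yet its nearest neighbour is compound 1, with a 1.1-fold higher number from compound 1 to compound 2 (0.03 log units; within the scatter), and the gap to compound 3, a 1.2-fold lower number from compound 2 to compound 3 (0.09 log units; within the scatter), also lies within the scatter, so no order among the three can be drawn.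

Compound 4 `COc1cc(/C=N/NC(=O)Nc2cc3c(Nc4ccc(F)c(Cl)c4)ncnc3cc2O[C@H]2CCOC2)cc(OC)c1OC` has not yet been measured in this assay. It differs from compound 2 in one place: 3,4,5-trimethoxyphenyl in place of 4-nitrophenyl on a carbon with a double bond to nitrogen. The step that bears most directly on this change is the one in which 2,3,4-trimethoxyphenyl took the place of 4-nitrophenyl, giving a 1.2-fold lower number from compound 2 to compound 3 (0.09 log units; within the scatter). The step of a 1.2-fold lower number from compound 1 to compound 3 (0.06 log units; within the scatter), where a trimethoxyphenyl again entered, tells the same story. Both stayed within the scatter, so the step expected here is a 1.2-fold lower number from compound 2 to compound 4 (0.06 log units; within the scatter), meaning nothing beyond the usual variation of repeated runs. On that basis compound 4 is estimated at 27000 nM, with a range from 12000 nM to 60000 nM.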

Compound 4, half-maximal inhibitory concentration: 26400 nM
Compound 4: middle estimate off by 1.0-fold (0.01 log units), on the high side; the range from low to high includes it.
By their numbers in this assay, from the lowest: compounds 3, 4, 1 and 2 (each within the scatter of the next).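

In this assay, for the compounds shown here, the earlier compounds held only one arrangement of three methoxy groups, and the second arrangement now gives a 1.0-fold higher number from compound 3 to compound 4 (0.02 log units; within the scatter), so within these two compounds the choice between 2,3,4-trimethoxyphenyl and 3,4,5-trimethoxyphenyl makes no readable difference. The same group also gives a 1.2-fold lower number from compound 2 to compound 4 (0.07 log units; within the scatter) when it replaces 4-nitrophenyl and a 1.1-fold lower number from compound 1 to compound 4 (0.04 log units; within the scatter) when it replaces 4-cyanophenyl, so swapping either of those rings for this larger, nitrogen-free group on the carbon with a double bond to nitrogen leaves the number within the usual variation of repeated runs. All four compounds now form a flat set at this position, and no measurement at hand offers an explanation for that flatness.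

Every compound shown carries a substituted phenyl ring at this place, so it remains open whether a ring bearing a dimethylamino group or a carboxylic acid, or a longer alkyl chain in place of the ring, would move the number beyond the scatter. Going by these compounds, it also remains open whether this flat picture would hold in a different cell line or with a change elsewhere on the shared core.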